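The source may hold more compounds than are shown below. What is called first, only, known or untested is meant among the compounds shown, and "the series" means these compounds.

Working notes on the series. Among the compounds with values here, three analogues of the shared core have numbers so far. In a functional assay, read by spectrophotometry, tested at 100 uM (on this read-out lower numbers stand for stronger inhibition and higher numbers for weaker inhibition), compound 1 `O=C(/C=C/c1ccccc1)c1cccc(NC(=O)c2cc(-c3ccncc3)n[nH]2)c1` gives 67100 nM, the second highest of the three; compound 2 `Cc1ccc(/C=C/C(=O)c2cccc(NC(=O)c3cc(-c4ccncc4)n[nH]3)c2)cc1` gives 69400 nM and compound 3 `CN(C)c1ccc(/C=C/C(=O)c2cccc(NC(=O)c3cc(-c4ccncc4)n[nH]3)c2)cc1` gives 41900 nM. The steps of a 1.0-fold higher number from compound 1 to compound 2 (0.01 log units; within the scatter), a 1.6-fold lower number from compound 1 to compound 3 (0.20 log units; within the scatter) and a 1.7-fold lower number from compound 2 to compound 3 (0.22 log units; within the scatter) all stay within the scatter, so substitution at this place has so far moved nothing. Compound 4 `COc1cc(/C=C/C(=O)c2cccc(NC(=O)c3cc(-c4ccncc4)n[nH]3)c2)cc(OC)c1OC` differs from compound 1 by 3,4,5-trimethoxyphenyl in place of phenyl on a double-bonded chain carbon bound to a double-bonded chain carbon. Within the data shown here, none of the measured steps involves the group entering here, but all three bear on substitution at the same place and were flat, so no step beyond the scatter is expected, as a 1.1-fold lower number from compound 1 to compound 4 (0.05 log units; within the scatter). Compound 4 is estimated at 60000 nM, with a range of 30000 nM to 120000 nM.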

Compound 4, half-maximal inhibitory concentration: 54500 nM
Beside the measured number, compound 4's estimate is 1.1-fold (0.04 log units) above it; the measured number falls inside the stated range.
By their numbers in this assay, from the lowest: compounds 3, 4, 1 and 2 (each within the scatter of the next).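

At the double-bonded chain carbon, the change to 3,4,5-trimethoxyphenyl, with its 3 hydrogen-bond acceptors, brings no step beyond the scatter in this assay (a 1.2-fold lower number from compound 1 to compound 4 (0.09 log units; within the scatter)) (a 1.3-fold higher number from compound 3 to compound 4 (0.11 log units; within the scatter)) (a 1.3-fold lower number from compound 2 to compound 4 (0.10 log units; within the scatter)). The flat picture thus extends from the single methyl and dimethylamino substituents to a three-methoxy pattern, and none of the four compounds goes against it. No supporting data bear on why this position stays flat. Open, on these data alone, is whether a carboxylic acid, or a pyridine ring in place of phenyl, would move the number here.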